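A few compounds are considered here, and "the series" means these few. Any claim that something is new, unique, unknown or untested is made for them only; others in the source may bear on it.

Compound 1 `O=C(/C=C\Nc1ccc(Cl)cc1)c1cn(-c2ccccc2)nc1-c1ccccc1` and compound 2 `COc1ccc(N/C=C\C(=O)c2cn(-c3ccccc3)nc2-c2ccccc2)cc1` share a core and differ in one place: methoxy in place of chloro on an aromatic carbon. In a functional assay on A549 cells (Homo sapiens) for antiproliferative activity, read by MTT assay, with a stated time of 48 h (a higher number here means a weaker inhibitor, a lower number a stronger inhibitor), compound 1 gives 14100 nM, and compound 2 gives 3250 nM; the step between them is a 4.3-fold lower number from compound 1 to compound 2 (0.64 log units; beyond the scatter). Compound 3 `O=C(/C=C\Nc1ccc(F)cc1)c1cn(-c2ccccc2)nc1-c1ccc(Cl)cc1` has a core whose difference from the core of compound 1 is not broken down here. In this assay compound 3 gives only a limit of the assay, > 50000 nM, (the limit of > 50000 nM in this assay, at which 1 of the 3 values shown sits). Compound 4 `COc1ccc(-c2nn(-c3ccccc3)cc2C(=O)/C=C\Nc2ccc(F)cc2)cc1` differs from compound 3 as follows: methoxy in place of chloro on an aromatic carbon. This is the same kind of change as that from compound 1 to compound 2, at the same kind of place, on an aromatic carbon of a six-membered aromatic ring of carbon only, para to a large group; read one bond further out, the earlier change also reads (4-chlorophenyl)amino to (4-methoxyphenyl)amino, whereas this one reads only 4-chlorophenyl to 4-methoxyphenyl. Since compound 3 is known only as a limit, the step to compound 4 is expected to be roughly an at least 1.4-fold lower number from compound 3 to compound 4 (0.15 log units; that floor lies within the scatter), resting on the earlier step of a 4.3-fold lower number from compound 1 to compound 2 (0.64 log units; beyond the scatter). Compound 4 is therefore estimated at 35000 nM, between 10000 nM and 120000 nM, with a real chance that only a limit is reported again.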

Compound 4, half-maximal inhibitory concentration: 3980 nM
Compound 4: middle estimate off by 8.8-fold (0.94 log units), on the high side, and the stated range ends above it.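

In this assay, methoxy in place of chloro again goes with a lower number on the second core, with an at least 12-fold lower number from compound 3 to compound 4 (1.09 log units; beyond the scatter), so the direction of the step holds across these two pairs while its size does not carry over: the same change on two cores in this assay, a 4.3-fold lower number (0.64 log units; beyond the scatter) from compound 1 to compound 2 and an at least 12-fold lower number (1.09 log units; beyond the scatter) from compound 3 to compound 4, at least 2.8-fold (0.46 log units) apart, beyond the scatter of two such steps

The full size of the second step cannot be read, since compound 3 stands only at a limit of the assay: the limit of > 50000 nM in this assay, at which 1 of the 4 values shown sits.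

Two pairs make no rule for the series, and they do not show which feature of the two cores goes with the larger step.

The compounds shown leave open whether the same change would give a lower number on further cores, and whether a step of either size would be seen on a core with only one of the differences between the core of compound 1 and the core of compound 3. They also leave open how an ethoxy group, a hydroxyl group or an amine would compare with methoxy at the same place.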